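A few compounds are considered here, and "the series" means these few. Any claim that something is new, unique, unknown or untested is made for them only; others in the source may bear on it.

Of the compounds shown here, three have been measured in an ADME assay on HEK-293T cells (Homo sapiens) for inhibition, read by CCK-8 assay, with a stated time of 48 h, tested at 20 uM; on this read-out higher numbers stand for more inhibition of growth at the one concentration tested and lower numbers for less inhibition of growth. Compound 1, `Cc1ccc(S(=O)(=O)Oc2ccccc2/C=C(\C#N)C(=O)Nc2nnc(Cc3cccc(F)c3)s2)cc1`, gives 9% in this assay. Compound 2, `COc1ccc(S(=O)(=O)Oc2ccccc2/C=C(\C#N)C(=O)Nc2nnc(Cc3cccc(F)c3)s2)cc1`, gives 29%. Compound 3, `Cc1ccc(S(=O)(=O)Oc2ccccc2/C=C(\C#N)C(=O)Nc2nnc(Cc3ccc(Cl)cc3)s2)cc1`, gives 20%. Compound 2 differs from compound 1 by methoxy in place of methyl on an aromatic carbon, and this brought a number 20 percentage points higher from compound 1 to compound 2 (beyond the scatter). Compound 3 differs from compound 1 by 4-chlorophenyl in place of 3-fluorophenyl on a saturated chain carbon bound to an aromatic carbon, which brought a number 11 percentage points higher from compound 1 to compound 3 (beyond the scatter). The values of compound 2 and compound 3 lie within the scatter of each other, so nothing separates them.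

Compound 4, `COc1ccc(S(=O)(=O)Oc2ccccc2/C=C(\C#N)C(=O)Nc2nnc(Cc3ccc(Cl)cc3)s2)cc1`, has not yet been measured. It differs from compound 3 by methoxy in place of methyl on an aromatic carbon, the same change as that from compound 1 to compound 2, here made on the core of compound 3 rather than on the core of compound 1. For the measured compounds named here, only one instance of this change has been measured, so any expectation rests on a single pair. In this assay a step of a number 17 percentage points higher from compound 3 to compound 4 (beyond the scatter) is expected, because a number 20 percentage points higher from compound 1 to compound 2 (beyond the scatter) was seen on the other core and the step is taken to carry over somewhat damped. Compound 4 is estimated at 37%, with a range from 22% to 54%.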

Compound 4, percent growth inhibition at one concentration: 26%
The estimate for compound 4 lay 11 percentage points above the measured number, and the stated range covers the measured number.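

In this assay the methoxy in place of methyl brings a number 6 percentage points higher from compound 3 to compound 4 (within the scatter), and its two instances do not differ beyond what the scatter allows: the same change on two cores in this assay, a number 20 percentage points higher (beyond the scatter) from compound 1 to compound 2 and a number 6 percentage points higher (within the scatter) from compound 3 to compound 4, 14 percentage points apart, within the scatter of two such steps. The 4-chlorophenyl in place of 3-fluorophenyl brings a number 3 percentage points lower from compound 2 to compound 4 (within the scatter), and its two instances likewise do not differ beyond the scatter: the same change on two cores in this assay, a number 11 percentage points higher (beyond the scatter) from compound 1 to compound 3 and a number 3 percentage points lower (within the scatter) from compound 2 to compound 4, 14 percentage points apart, within the scatter of two such steps. These pairs give no sign that either change depends on the core, but they do not show that either step carries over, since each lies beyond the scatter only when made from compound 1 and within it on the second core, and one pair per core cannot settle the matter.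

The compounds shown leave open how an amine or a carboxylic acid would read in place of methyl on the aromatic carbon para to a large group. They also leave open whether a longer chain in place of the saturated chain carbon would shift the read-out on either core.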